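Trifluoromethyl for Fluoro: Expected Cytotoxicity of Compound 4

This account rests on a few compounds, and the source may have more. Where it says the series, first, only, none or still open, it means among the compounds named here.

Three compounds share a propenamide arm attached to a five-membered ring that carries a phenyl group, and all were tested in an ADME assay on NIH3T3 cells (Mus musculus) for cytotoxicity, read by CCK-8 assay, with a stated time of 24 h; a higher number here means a weaker inhibitor, a lower number a stronger inhibitor. Compound 1, with structure `C/C(=C\c1cc(-c2ccccc2)co1)C(N)=O`, reaches only the limit of the measurement, giving > 50000 nM. Compound 2, with structure `C/C(=C\c1cc(-c2ccc(F)cc2)co1)C(N)=O`, likewise sits at the limit, giving > 50000 nM. Compound 3, with structure `C/C(=C\c1cc(-c2ccc(F)cc2)cs1)C(N)=O`, also stops at the limit, giving > 50000 nM. Within the data shown here, the single step between neighbours that differ in one place, a step that the two limits leave unreadable from compound 1 to compound 2, therefore cannot be read as a number. Compound 3 thus stands where every value here stands: the limit of > 50000 nM in this assay, at which 3 of the 3 values shown sit.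

Compound 4, with structure `C/C(=C\c1cc(-c2ccc(C(F)(F)F)cc2)cs1)C(N)=O`, differs from compound 3 in one place: trifluoromethyl in place of fluoro on an aromatic carbon. Among the measured compounds shown here, no measured step involves a trifluoromethyl group, and the only measured step, from compound 1 to compound 2, is unreadable, so nothing here shows a direction for this change. Compound 4 is therefore expected to behave like its three neighbours in this assay, most likely again at the limit, with an estimated value of 60000 nM and a range from 20000 nM to 200000 nM. The step from compound 3 to compound 4 is expected to be a step that the limit leaves unreadable from compound 3 to compound 4.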

Compound 4, half-maximal inhibitory concentration: > 50000 nM
Compound 4 was reported as a limit; the forecaster's own chance of this, stated with the estimate: 80%; the middle value is on the limit's open side.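

In this assay compound 4 gives > 50000 nM, which is a limit and not a number. Compound 3 is reported as a limit too, so no step can be read between compound 3 and compound 4, and all four compounds stand at the same place: the limit of > 50000 nM in this assay, at which 4 of the 4 values shown sit. On these data alone, whether swapping fluoro for trifluoromethyl changes cytotoxicity at all, and how any of these four compounds rank against each other, stays open.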